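Amide Substituent Size and Antiproliferative Potency

The source may hold more compounds than are shown below. What is called first, only, known or untested is meant among the compounds shown, and "the series" means these compounds.

Measured compounds:
- compound 1, `CCC1C(=O)N(C)c2cnc(-n3ccc4cc(C(=O)NC(C)C)ccc43)nc2N1c1ccn(C)n1`: 8420 nM
- compound 2, `CCC1C(=O)N(C)c2cnc(-n3ccc4cc(C(=O)NC)ccc43)nc2N1c1ccn(C)n1`: 35400 nM
- compound 3, `CC[C@@H]1C(=O)N(C)c2cnc(-n3ccc4cc(C(=O)NC)ccc43)nc2N1C1CCCC1`: 1000 nM

All three compounds were tested in a functional assay on MCF7 cells (Homo sapiens) for antiproliferative activity, read by CCK-8 assay, with a stated time of 72 h; a higher number here means a weaker inhibitor of growth, a lower number a stronger inhibitor of growth. In this assay compound 2 gives 35400 nM, while compound 1 gives 8420 nM. The two share one core and differ in a single spot, described as isopropyl in place of methyl on an amide-type nitrogen. That change made the step of a 4.2-fold lower number from compound 2 to compound 1 (0.62 log units; beyond the scatter), so the larger group on the amide nitrogen went together with stronger growth inhibition.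

Compound 3 carries a different core, and in this assay compound 3 gives 1000 nM, the lowest number among the three. The difference between the core of compound 3 and the core of compound 2 is not broken down here.

Compound 4, `CC[C@@H]1C(=O)N(C)c2cnc(-n3ccc4cc(C(=O)NC(C)C)ccc43)nc2N1C1CCCC1`, has not yet been measured. It differs from compound 3 as isopropyl in place of methyl on an amide-type nitrogen, which is the same change, at the same kind of position, that took compound 2 to compound 1. Because that earlier step was a 4.2-fold lower number from compound 2 to compound 1 (0.62 log units; beyond the scatter), a step of similar direction is expected here, though the new core of compound 3 gives no guarantee that its size will carry over. The expected step is a 3.3-fold lower number from compound 3 to compound 4 (0.52 log units; beyond the scatter). On this basis compound 4 is estimated to reach 300 nM in this assay, with a likely range from 100 nM to 900 nM.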

Compound 4, concentration for 50% growth inhibition: 1670 nM
Compound 4: middle estimate off by 5.6-fold (0.75 log units), on the low side; measured number outside the range, above it.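

On the core of compound 3, the same swap of methyl for isopropyl on the amide nitrogen gave a 1.7-fold higher number from compound 3 to compound 4 (0.22 log units; within the scatter), so in this assay the two compounds cannot be told apart. Set side by side, the two steps show that the effect of this change did not carry over from one core to the other, and that the step seen on the first core is a poor guide to the step on the second: the same change on two cores in this assay, a 4.2-fold lower number (0.62 log units; beyond the scatter) from compound 2 to compound 1 and a 1.7-fold higher number (0.22 log units; within the scatter) from compound 3 to compound 4, 7.0-fold (0.85 log units) apart, beyond the scatter of two such steps. Among the compounds shown here, this shows that the core can matter to the outcome of this change, but with only two pairs it does not show which feature of the cores is responsible, why the steps differ, or what the same change would do on a third core.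

The compounds shown leave open how other groups on the amide nitrogen would behave on these two cores, for example ethyl, cyclopropyl, a longer chain such as butyl, or a chain ending in an amine. They also leave open whether a plain amide, with the amide nitrogen carrying only hydrogens, would follow the first core's step or the second's.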